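From compound 3 to compound 4: an alkenyl isomer swap

The compounds below may be only part of what the source reports. "The series", "measured", "known", "first", "only" and "open" are said of these compounds alone.

Measured in a functional assay on A549 cells (Homo sapiens) for inhibition, read by MTT assay, with a stated time of 72 h; on this read-out lower numbers stand for stronger inhibition and higher numbers for weaker inhibition:
- compound 1 `CCC/C=C\C(=O)Nc1cc(Nc2nc3c(c(-c4cn(C)c5ccc(F)cc45)n2)CSCC3)c(OC)cc1N(C)CCN(C)C`: 5190 nM
- compound 2 `C=CC(=O)Nc1cc(Nc2nc3c(c(-c4cn(C)c5ccccc45)n2)CS(=O)(=O)CC3)c(OC)cc1N(C)CCN(C)C`: 8690 nM
- compound 3 `COc1cc(N(C)CCN(C)C)c(NC(=O)C=C(C)C)cc1Nc1nc2c(c(-c3cn(C)c4ccccc34)n1)CS(=O)(=O)CC2`: 787 nM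

Compound 3, at 787 nM, has the lowest of the three numbers. The next change leads to compound 4 `CC/C=C\C(=O)Nc1cc(Nc2nc3c(c(-c4cn(C)c5ccccc45)n2)CS(=O)(=O)CC3)c(OC)cc1N(C)CCN(C)C`: but-1-en-1-yl in place of 2-methylprop-1-en-1-yl on a carbonyl carbon. The two have the same atoms, joined differently, with but-1-en-1-yl in place of 2-methylprop-1-en-1-yl on a carbonyl carbon.

Within the data shown here, the one measured step at this place is an 11-fold lower number from compound 2 to compound 3 (1.04 log units; beyond the scatter), a large change with 2-methylprop-1-en-1-yl in place of vinyl. It shows that this position can move the number well beyond the scatter. Among the measured compounds shown here, no measured compound pairs but-1-en-1-yl with the core of compound 4, however. Compound 1, at 5190 nM, differs from the others in more than one place and offers only weak support.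

A partial return towards the higher numbers is expected, and the estimated change in this assay is a 3.2-fold higher number from compound 3 to compound 4 (0.50 log units; beyond the scatter).

Compound 4 is estimated at 2500 nM, with an expected range of 800 nM to 7500 nM.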

Compound 4, half-maximal inhibitory concentration: 1350 nM
Estimate against measurement, compound 4: 1.9-fold (0.27 log units) above, and the stated range covers the measured number.
By their numbers in this assay, from the lowest: compounds 3 and 4 (each within the scatter of the next); then compounds 1 and 2 (each within the scatter of the next).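

In this assay the swap on the carbonyl carbon gives a 1.7-fold higher number from compound 3 to compound 4 (0.23 log units; within the scatter) and so does not separate but-1-en-1-yl from 2-methylprop-1-en-1-yl. Against vinyl, but-1-en-1-yl gives a 6.4-fold lower number from compound 2 to compound 4 (0.81 log units; beyond the scatter) and so joins the earlier 11-fold lower number from compound 2 to compound 3 (1.04 log units; beyond the scatter) in showing that the lower number on this core is not confined to 2-methylprop-1-en-1-yl. No measurement available here explains why these two groups read alike or why both differ from vinyl.

Still open, from the compounds shown here alone, is how a longer alkenyl chain, or an amine carried on the but-1-en-1-yl chain, would read on the core of compound 4. Going by these compounds, the other double-bond geometry of but-1-en-1-yl is also open, and a reading from it would show whether the shape of this group matters.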